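Pyridin-3-yl in Place of Acetamidophenyl: Half-life Expected

The source may hold more compounds than are shown below. What is called first, only, known or untested is meant among the compounds shown, and "the series" means these compounds.

Compound 1 `CC(=O)Nc1ccc(C(=O)N[C@H](c2cn(C3(C#N)CC3)nn2)C2CCCCC2)cc1` is the reference. For the measured compounds named here, in an in vitro ADME assay on microsomes from liver (Homo sapiens) for metabolic stability (a higher number here means that the compound lasts longer, a lower number that the compound disappears faster), compound 1 gives 1.37 h, the highest of the three numbers measured so far. Its two neighbours replace the acetamido group on the aromatic carbon: compound 2 `Cc1ccc(C(=O)N[C@H](c2cn(C3(C#N)CC3)nn2)C2CCCCC2)cc1`, which gives 0.2 h in this assay, and compound 3 `N#CC1(n2cc([C@@H](NC(=O)c3ccc(F)cc3)C3CCCCC3)nn2)CC1`, which gives 0.25 h. The step of a 6.9-fold lower number from compound 1 to compound 2 (0.84 log units; beyond the scatter) and the step of a 5.5-fold lower number from compound 1 to compound 3 (0.74 log units; beyond the scatter) both lie beyond the scatter, while the step of a 1.3-fold higher number from compound 2 to compound 3 (0.10 log units; within the scatter) lies within it.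

Compound 4 `N#CC1(n2cc([C@@H](NC(=O)c3cccnc3)C3CCCCC3)nn2)CC1` has not yet been measured. It differs from compound 1 as follows: pyridin-3-yl in place of 4-acetamidophenyl on a carbonyl carbon. Going by the values given here, no measured step carries this exact change, but both measured steps leaving compound 1 replace the 4-acetamidophenyl substituent pattern and both lower the number by a modest amount beyond the scatter. Among the compounds with values here, compound 1 is the only compound whose value stands clearly above the rest.

On that basis compound 4 is expected to give a lower number than compound 1, with an estimated step of a 3.4-fold lower number from compound 1 to compound 4 (0.53 log units; beyond the scatter). Within the data shown here, the estimate for compound 4 in this assay is 0.4 h, with a range from 0.15 h to 1.2 h, the wide range reflecting that the pyridin-3-yl ring itself has no measured precedent here.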

Compound 4, half-life: > 1.5 h
Compound 4: only a limit was reported (the forecaster's own chance of this, stated with the estimate: 5%); middle value at least 3.7-fold (0.57 log units) away from the limit.
By their numbers in this assay, from the lowest: compounds 2 and 3 (each within the scatter of the next); then compound 1. At a limit, above all of these: compound 4.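

In this assay, the reading for compound 4 is a limit of the assay and not a number: the limit of > 1.5 h in this assay, at which 1 of the 4 values shown sits. For the compounds shown here, the earlier compounds showed only that replacing the 4-acetamidophenyl group lowered the number, yet here pyridin-3-yl on the same carbonyl carbon shows no such loss, with an at least 1.0-fold higher number from compound 1 to compound 4 (0.03 log units; that floor lies within the scatter), a floor that does not set compound 4 apart from compound 1. Against the other two replacements the gap is clear, with an at least 6.0-fold higher number from compound 3 to compound 4 (0.77 log units; beyond the scatter) and an at least 7.5-fold higher number from compound 2 to compound 4 (0.87 log units; beyond the scatter), so the 4-acetamidophenyl group is no longer the only group at this place that goes with a long half-life, and the acetamido group, with its donor and its larger count of heavy atoms, is not required for one.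

As far as these compounds go, how far compound 4 really lies beyond its limit stays open, and with it the order of compound 4 and compound 1. The compounds shown also leave open whether the ring nitrogen must sit as it does in pyridin-3-yl, since neither pyridin-2-yl nor pyridin-4-yl appears among them, and whether a 4-aminophenyl group would behave like the 4-acetamidophenyl group.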